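Chain extension on the core of compound 1

The compounds below may be only part of what the source reports. "The series", "measured", "known", "first", "only" and "open" are said of these compounds alone.

Measured so far, in a functional assay for inhibition, with Homo sapiens as the target; on this read-out higher numbers stand for weaker inhibition and lower numbers for stronger inhibition:
compound 1, `C=CCn1ncc2c(CC)ncn2c1=O`, gives > 48000 nM, a limit of the assay rather than a number.
compound 2, `COCc1ncc2cnnc(S)n12`, gives > 48000 nM, also a limit.
compound 3, `CCCc1ncn2c(O)nncc12`, gives > 48000 nM, also a limit.

Compound 1 therefore stands only at a limit in this assay, and no number places it relative to anything else; the limit of > 48000 nM in this assay, at which 3 of the 3 values shown sit, covers every value shown. The step to compound 4, `C=CCn1ncc2c(CCC)ncn2c1=O`, is methyl in place of hydrogen on a saturated chain carbon, two bonds along the chain from an aromatic carbon. Among the compounds with values here, no measured step between compounds of this kind exists here, so the expected step is a step that the limit leaves unreadable from compound 1 to compound 4, none beyond the scatter. Compound 4 is expected to give 60000 nM, within 30000 nM to 120000 nM, most likely again reported only as a limit.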

Compound 4, half-maximal inhibitory concentration: > 48000 nM
Compound 4: no number, only a limit (the forecaster's own chance of this, stated with the estimate: 85%); the middle value does not contradict the limit.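

No step can be read between compound 1 and compound 4, since each stands only at a limit: the limit of > 48000 nM in this assay, at which 4 of the 4 values shown sit. The compounds shown leave open whether chain length on the core of compound 1 affects inhibition at all.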